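A few compounds are considered here, and "the series" means these few. Any claim that something is new, unique, unknown or untested is made for them only; others in the source may bear on it.

Compound 1, `CNC(=O)c1cc(Oc2ccc(C(=O)/C=C/c3ccco3)cc2)ccn1`, shows the shared core of this small series; in a functional assay on MCF7 cells (Homo sapiens) for cytotoxicity, read by MTT assay, with a stated time of 72 h (a lower number here means a stronger inhibitor, a higher number a weaker inhibitor), compound 1 carries no result, "not determined" (no result reported). Compound 2, `CNC(=O)c1cc(Oc2ccc(C(=O)/C=C/c3cccc(Br)c3)cc2)ccn1`, in this assay gives 10400 nM. Compound 3, `CNC(=O)c1cc(Oc2ccc(C(=O)/C=C/c3ccc(Br)cc3)cc2)ccn1`, in this assay reaches only a limit of the assay, > 50000 nM. Moving the bromo from one ring position to the other is recorded as an at least 4.8-fold higher number from compound 2 to compound 3 (0.68 log units; beyond the scatter), and the true size of that step stays open, since compound 3 sits at the limit of > 50000 nM in this assay, at which 1 of the 3 values shown sits, rather than at a measured number.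

Compound 4, `CNC(=O)c1cc(Oc2ccc(C(=O)/C=C/c3ccc(F)cc3)cc2)ccn1`, differs from compound 3 by fluoro in place of bromo on an aromatic carbon. Within the data shown here, no measured step in this set swaps bromo for fluoro on that ring, so the one step that bears on compound 4, from compound 2 to compound 3, speaks only about where the halogen sits, not about which halogen it is. Among the measured compounds shown here, with compound 3 already past the upper edge of what this assay can report, the change to fluoro has no measured precedent to move the expectation in either direction. Compound 4 is therefore expected to give 60000 nM, within a range from 15000 nM to 200000 nM. The expected step that the limit leaves unreadable from compound 3 to compound 4 is thus estimated to stay within the scatter, with a real chance that compound 4 again yields only a limit.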

Compound 4, half-maximal inhibitory concentration: 28500 nM
The estimate for compound 4 lay 2.1-fold (0.32 log units) above the measured number; the range from low to high includes it.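

In this assay, among these compounds, fluoro in place of bromo on this aromatic carbon, para to a large group, is recorded as an at least 1.7-fold lower number from compound 3 to compound 4 (0.24 log units; that floor lies within the scatter), and compound 4 supplies the first measured number for a halogen at this ring position. From the compounds shown here alone, compound 3 remains a limit and not a number, so the true size of the halogen change stays open because of that limit: the limit of > 50000 nM in this assay, at which 1 of the 4 values shown sits. The 3-bromophenyl compound still holds the lower number, with a 2.7-fold higher number from compound 2 to compound 4 (0.44 log units; beyond the scatter), which shows that the gap between these two ring positions does not rest on the limit alone, although this step changes both the halogen and its place.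

These compounds cannot tell whether the lower number of the 3-bromophenyl compound belongs to the bromo group itself or to where it sits, since no fluoro compound with that placement is shown. Going by these compounds, it also stays open how chloro, methoxy or an amine on the same aromatic carbon would read in this assay, and whether any of them would give a number well clear of the limit.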